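Swapping the aryl ether group in a cytotoxicity series

The source may report more compounds than this note shows. Statements on the series, on what has been measured and on what is new or still open speak of the compounds shown alone.

Three compounds built on one shared core differ only in the aryl group attached through an oxygen, and all three were tested in an ADME assay on MT4 cells (Homo sapiens) for cytotoxicity, read by MTT assay, with a stated time of 4 days; on this read-out higher numbers stand for lower toxicity in this test and lower numbers for higher toxicity in this test. Compound 1 `COc1ccc(Oc2nc(Nc3ccc(C#N)cc3)nc3ccccc23)cc1` gives 340000 nM. Compound 2 `N#Cc1ccc(Nc2nc(Oc3ccc(Cl)cc3)c3ccccc3n2)cc1` gives 198000 nM, which sits at the low end of the three numbers, while compound 3 `COc1cc(C#N)cc(Cl)c1Oc1nc(Nc2ccc(C#N)cc2)nc2ccccc12` gives 220000 nM, close to compound 2. Among the compounds with values here, the single one-point step among the measured compounds, chloro in place of methoxy on an aromatic carbon, is a 1.7-fold lower number from compound 1 to compound 2 (0.23 log units; within the scatter), so the numbers seen so far hardly move with this kind of change.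

Compound 4 `Cc1cccc(Oc2nc(Nc3ccc(C#N)cc3)nc3ccccc23)c1` has not been measured. It differs from compound 2 by 3-methylphenyl in place of 4-chlorophenyl on an oxygen on an aromatic ring. Within the data shown here, no measured step replaces a chloro by a methyl or moves a group from one ring position to another, so nothing in the data points to a shift in either direction; the only step available, chloro in place of methoxy, stayed inside the scatter. The expected step from compound 2 to compound 4 is therefore a 1.2-fold higher number from compound 2 to compound 4 (0.08 log units; within the scatter), meaning no change beyond the scatter. Compound 4 is thus estimated to give 240000 nM in this assay, with a likely range from 110000 nM to 500000 nM.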

Compound 4, half-maximal cytotoxic concentration: 355000 nM
Beside the measured number, compound 4's estimate is 1.5-fold (0.17 log units) below it; measured number inside the range.
By their numbers in this assay, from the lowest: compounds 2, 3, 1 and 4 (each within the scatter of the next).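

The new compound gives a second and third reading of the group on this oxygen in this assay. Putting 3-methylphenyl in place of 4-chlorophenyl gives a 1.8-fold higher number from compound 2 to compound 4 (0.25 log units; within the scatter) and putting 3-methylphenyl in place of 4-methoxyphenyl gives a 1.0-fold higher number from compound 1 to compound 4 (0.02 log units; within the scatter) so neither swap moves the number beyond the usual scatter, even though the substituent and its name-given ring location both differ. Together with the earlier chloro-for-methoxy step, this means that all three one-place steps among compounds 1, 2 and 4 now lie within the scatter, which makes the flat result at this place firmer than a single step could, although no measurement shown offers an explanation for it.

Going by these compounds, what remains open is whether this flatness extends to very different groups at the same oxygen, such as an aryl ring carrying an amine or a carboxylic acid, or a longer chain in place of the ring. The compounds shown also say nothing about whether any change at this place can produce a step beyond the scatter in this assay at all.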